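This account rests on a few compounds, and the source may have more. Where it says the series, first, only, none or still open, it means among the compounds named here.

In an assay for inhibition of sodium- and chloride-dependent glycine transporter 1 (Homo sapiens) (a higher number here means a weaker inhibitor, a lower number a stronger inhibitor), compound 3 `CC1CN(c2ccccc2Sc2ccc(O)cc2)C(C)CN1CC(=O)O` gives 3600 nM, the highest number among the three compounds measured here. Compound 1 `COc1ccc(Sc2ccccc2N2CC(C)N(CC(=O)O)CC2C)cc1` gives 580 nM, and compound 2 `CC1CN(c2ccccc2Sc2ccc(Cl)cc2)C(C)CN1CC(=O)O` gives 360 nM. Compound 4 `CC(=O)Nc1ccc(Sc2ccccc2N2CC(C)N(CC(=O)O)CC2C)cc1` carries acetamido in place of hydroxy on an aromatic carbon. For the measured compounds named here, two measured steps bear on this change, since both end at the hydroxy group of compound 3: a 6.2-fold higher number from compound 1 to compound 3 (0.79 log units; beyond the scatter), and a 10-fold higher number from compound 2 to compound 3 (1.00 log units; beyond the scatter). Compound 3 therefore stands well behind compounds 1 and 2, and a step away from hydroxy is expected to run the other way. Acetamido differs from both groups already tested, and no measurement of it is available here, so only part of that gain is taken as likely: compound 4 is expected to give 900 nM, between 300 nM and 3000 nM, meaning a 4.0-fold lower number from compound 3 to compound 4 (0.60 log units; beyond the scatter).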

Compound 4, half-maximal inhibitory concentration: 22000 nM
Compound 4: the middle estimate sits 24-fold (1.39 log units) below what was measured; measured number outside the range, above it.
By their numbers in this assay, from the lowest: compounds 2 and 1 (each within the scatter of the next); then compound 3; then compound 4.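

On an aromatic carbon para to a large group, acetamido gives the weakest result of the four groups in this assay and falls further than hydroxy (a 6.1-fold higher number from compound 3 to compound 4 (0.79 log units; beyond the scatter)), with larger losses against methoxy (a 38-fold higher number from compound 1 to compound 4 (1.58 log units; beyond the scatter)) and chloro (a 61-fold higher number from compound 2 to compound 4 (1.79 log units; beyond the scatter)). Hydroxy and acetamido have the same count of hydrogen-bond donors and acceptors, so that count alone does not set the result across this pair. Nothing measured here explains the loss.

As far as these compounds go, it remains open how an amine or a methyl group would perform here. A longer amide, such as propionamido, is also untested among these compounds.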